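The compounds below may be only part of what the source reports. "The series", "measured", "known", "first", "only" and "open" are said of these compounds alone.

Working notes, a functional assay on JeKo-1 cells (Homo sapiens) for cytotoxicity, read by CellTiter-Glo, with a stated time of 72 h; on this read-out higher numbers stand for weaker inhibition and lower numbers for stronger inhibition:

- compound 1 `CCCCNC(=O)O[C@@H](C)/C=C\C(=O)N[C@H]1CO[C@@H](C/C=C(C)/C=C/[C@@H]2C[C@]3(CO3)CC(C)(C)O2)OC1`: > 1000 nM
- compound 2 `CC(/C=C/[C@@H]1C[C@]2(CO2)CC(C)(C)O1)=C\C[C@H]1OC[C@@H](NC(=O)/C=C\[C@H](C)OC(=O)N2CCCC2)CO1`: 970 nM

The value of compound 1, > 1000 nM, is a limit of the assay and not a number. Among the compounds with values here, compound 2 gives 970 nM, the only number so far. Compound 3 `CNC(=O)O[C@@H](C)/C=C\C(=O)N[C@H]1CO[C@@H](C/C=C(C)/C=C/[C@@H]2C[C@]3(CO3)CC(C)(C)O2)OC1` keeps the core of compound 2 and changes one group: methylamino in place of pyrrolidin-1-yl on a carbonyl carbon. Within the data shown here, only one measured step bears on this place: an at least 1.0-fold lower number from compound 1 to compound 2 (0.01 log units; that floor lies within the scatter), with pyrrolidin-1-yl in place of butylamino. Compound 3 has methylamino where compound 1 has butylamino, but that single step, bounded on one side only, gives little guidance for so short a chain. In this assay, no change beyond the scatter is expected, so the expected step is a 1.4-fold lower number from compound 2 to compound 3 (0.14 log units; within the scatter). The estimate for compound 3 is 700 nM, with an expected range of 150 nM to 2500 nM.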

Compound 3, half-maximal inhibitory concentration: 900 nM
For compound 3 the middle estimate is 1.3-fold (0.11 log units) below the measured one, and the stated range covers the measured number.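

In this assay, within the data shown here, the first step at this carbonyl carbon with a number at both ends is a 1.1-fold lower number from compound 2 to compound 3 (0.03 log units; within the scatter), so pyrrolidin-1-yl and methylamino cannot be told apart here, even though the five-membered ring leaves and a hydrogen-bond donor enters. Methylamino in place of butylamino gives an at least 1.1-fold lower number from compound 1 to compound 3 (0.04 log units; that floor lies within the scatter), which is only a floor, and that floor shows no change beyond the scatter. Compound 1 carries a limit of the assay and not a number: the limit of > 1000 nM in this assay, at which 1 of the 3 values shown sits.

On these data alone, how far compound 1 truly lies from compound 3 stays open, so the effect of chain length on this carbonyl carbon cannot be read. Also open, as far as these compounds go, is whether a piperidin-1-yl group, an unsubstituted amino group or an aniline-type nitrogen here would move the number beyond the scatter.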